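A few compounds are considered here, and "the series" means these few. Any claim that something is new, unique, unknown or untested is made for them only; others in the source may bear on it.

Measured in a functional assay on COLO 205 cells (Homo sapiens) for inhibition, read by MTT assay, with a stated time of 48 h (a higher number here means a weaker inhibitor, a lower number a stronger inhibitor), so far:
- compound 1 `COc1cc(C(=O)/C=C/c2cccc(O)c2)cc(OC)c1OC` gives 49000 nM
- compound 2 `COc1cc(C(=O)/C=C/c2ccccc2C=O)cc(OC)c1OC` gives 88000 nM

On these two numbers, compound 2 stands within the scatter of compound 1, so no order can be read from the pair. Among the measured compounds shown here, the only measured step (a 1.8-fold higher number from compound 1 to compound 2 (0.25 log units; within the scatter)) put 2-formylphenyl in place of 3-hydroxyphenyl on a double-bonded chain carbon bound to a double-bonded chain carbon.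

Compound 3 `COc1cc(C(=O)/C=C/c2ccc(C=O)cc2)cc(OC)c1OC` keeps the shared core and carries 4-formylphenyl in place of 2-formylphenyl at that same place (4-formylphenyl in place of 2-formylphenyl on a double-bonded chain carbon bound to a double-bonded chain carbon). For the measured compounds named here, no measured step exchanges these two groups, so the data give no direct guide to this change. Going by the values given here, the one exchange measured at this place stayed within the scatter (a 1.8-fold higher number from compound 1 to compound 2 (0.25 log units; within the scatter)), and that is the sole basis for expecting no step beyond the scatter in this assay and no particular direction. The expected change is small (a 1.4-fold lower number from compound 2 to compound 3 (0.13 log units; within the scatter)). Compound 3 is estimated at 65000 nM (expected range 28000 nM to 140000 nM).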

Compound 3, half-maximal inhibitory concentration: 68800 nM
The estimate for compound 3 lay 1.1-fold (0.02 log units) below the measured number, within the range that was stated.
By their numbers in this assay, from the lowest: compounds 1, 3 and 2 (each within the scatter of the next).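

In this assay, 4-formylphenyl in place of 2-formylphenyl on a double-bonded chain carbon bound to a double-bonded chain carbon gives a 1.3-fold lower number from compound 2 to compound 3 (0.11 log units; within the scatter), so this exchange between two groups of the same atom makeup does not separate them in this assay. At the same place, 4-formylphenyl in place of 3-hydroxyphenyl gives a 1.4-fold higher number from compound 1 to compound 3 (0.15 log units; within the scatter), and with the earlier 1.8-fold higher number from compound 1 to compound 2 (0.25 log units; within the scatter), all three pairs among compound 1, compound 2 and compound 3 now stand within the scatter, so 3-hydroxyphenyl, 2-formylphenyl and 4-formylphenyl cannot be put in any order. No other evidence bears on these steps, and the numbers alone offer no explanation for them.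

The compounds shown leave open whether any group at this place can produce a step beyond the scatter, for example a phenyl ring carrying an amine or a carboxylic acid in place of the formyl or hydroxyl group. They also leave open whether a change elsewhere on the shared core, such as a longer chain in place of one of the methoxy groups, would move the number in this assay further than these exchanges have.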